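Chloro substitution on the core of compound 1

The source may hold more compounds than are shown below. What is called first, only, known or untested is meant among the compounds shown, and "the series" means these compounds.

Among the compounds with values here, compound 1 `ClCc1ccc(Cn2cnc3c(Cl)ncnc32)cc1` gives the lowest of the three numbers so far in a functional assay on HCC 2998 cells (Homo sapiens) for cytotoxicity, read by sulforhodamine B assay, with a stated time of 48 h (a lower number here means a stronger inhibitor of growth, a higher number a weaker inhibitor of growth), at 2040 nM. Compound 3 `ClCc1cccc(Cn2cnc3ncnc(Cl)c32)c1` gives 3230 nM and compound 2 `ClCc1ccccc1Cn1cnc2c(Cl)ncnc21` gives 3540 nM; both lie within the scatter of compound 1, so no order among the three can be read. Compound 4 `ClCc1ccc(Cn2cnc3c(Cl)nc(Cl)nc32)cc1` has not been measured. It differs from compound 1 by chloro in place of hydrogen on an aromatic carbon. Within the data shown here, no measured pair shares this change, so there is nothing to set its size by. In this assay the step from compound 1 to compound 4 is expected to stay within the scatter, in either direction. Compound 4 is estimated at 1800 nM, with a range of 600 nM to 5500 nM. The step this implies is expected to be a 1.1-fold lower number from compound 1 to compound 4 (0.05 log units; within the scatter).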

Compound 4, concentration for total growth inhibition: 24000 nM
The estimate for compound 4 lay 13-fold (1.12 log units) below the measured number; the measured number lies above the stated range.
By their numbers in this assay, from the lowest: compounds 1, 3 and 2 (each within the scatter of the next); then compound 4.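

In this assay, within the data shown here, chloro in place of hydrogen on the aromatic carbon between two ring nitrogen atoms gives a 12-fold higher number from compound 1 to compound 4 (1.07 log units; beyond the scatter) and is the first change with a step beyond the scatter. The earlier compounds shown here all carry hydrogen on this carbon, so they could not show that this position responds so strongly to this substitution. Nothing available accounts for the size of this step.

Open, going by these compounds, is whether an amine or a methoxy group on this carbon would give a like step. Also open, on these data alone, is whether chloro here would do the same in compound 2 and compound 3.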